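This account rests on a few compounds, and the source may have more. Where it says the series, first, only, none or still open, it means among the compounds named here.

Compound 1 `CCCC(Oc1ccc(-n2cc(C#N)cn2)cc1)c1ccc(C(=O)NCCC(=O)O)cc1` and compound 2 `CCCC(Oc1ccc(-n2cc3c(n2)CCCC3)cc1)c1ccc(C(=O)NCCC(=O)O)cc1` share one core and differ only in the ring system attached to the aromatic carbon. In a functional assay on cells for antagonist activity at Glucagon receptor (Homo sapiens), read by cAMP accumulation, in the presence of a further agent that is not named here (a higher number here means a weaker inhibitor, a lower number a stronger inhibitor), compound 1 gives only a limit, > 50000 nM, and not a number. For the measured compounds named here, compound 2 gives 4200 nM in this assay, the single measured number here. The step of an at least 11-fold lower number from compound 1 to compound 2 (1.07 log units; beyond the scatter) is known only as a bound because of the limit of > 50000 nM in this assay, at which 1 of the 2 values shown sits. Compound 3 `CCCC(Oc1ccc(-n2cccn2)cc1)c1ccc(C(=O)NCCC(=O)O)cc1` has not yet been measured; it differs from compound 2 as follows: a group of 5 heavy atoms (3 carbon, 2 nitrogen; one five-membered aromatic ring with 2 hetero atoms) in place of a group of 9 heavy atoms (7 carbon, 2 nitrogen; one five-membered aromatic ring with 2 hetero atoms, one six-membered non-aromatic ring of carbon only), on an aromatic carbon. Going by the values given here, no measured step removes this six-membered non-aromatic ring on its own, so the only guide is that the step which brought the larger group in was large. The step from compound 2 to compound 3 is therefore expected to be a weakening, a 3.6-fold higher number from compound 2 to compound 3 (0.55 log units; beyond the scatter), with wide uncertainty. Compound 3 is expected to give 15000 nM, between 4000 nM and 50000 nM.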

Compound 3, antagonist equilibrium constant: > 55000 nM
Compound 3: a limit, no number (the forecaster's own chance of this, stated with the estimate: 35%); at least 3.6-fold (0.56 log units) between middle value and limit.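

The new step is an at least 13-fold higher number from compound 2 to compound 3 (1.11 log units; beyond the scatter), measured in this assay, and it shows that taking away the six-membered non-aromatic ring and leaving plain 1H-pyrazol-1-yl loses the measurable activity. Compound 3 gives a limit and not a number, so this step is known only as a bound: the limit of > 55000 nM in this assay, at which 1 of the 3 values shown sits.

Compound 3 carries neither the cyano group nor the six-membered ring, so the gain seen with compound 2 cannot come from losing the cyano group alone, and among these compounds only the ring goes with a measured value. On these data alone, the step between compound 1 and compound 3 cannot be read, so what cyano does on this ring stays open. As far as these compounds go, it also stays open whether the whole six-membered ring is needed, or whether a smaller carbon group, such as methyl or cyclopropyl, on the 1H-pyrazol-1-yl would serve as well.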